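A few compounds are considered here, and "the series" means these few. Any claim that something is new, unique, unknown or untested is made for them only; others in the source may bear on it.

Measured so far in a functional assay on A549 cells (Homo sapiens) for cytotoxicity, read by MTT assay, with a stated time of 72 h; a lower number here means a stronger inhibitor, a higher number a weaker inhibitor:

Compound 1 `CN(C)CCn1cnnc1-c1cc(Oc2ccc(NC(=O)N/N=C/c3ccc(O)c(O)c3)cc2F)ccn1`. In this assay compound 1 gives > 100000 nM, a limit of the assay.
Compound 2 `CN(C)CCn1cnnc1-c1cc(Oc2ccc(NC(=O)N/N=C/c3cc(Br)c(O)c(Br)c3)cc2F)ccn1`. In this assay compound 2 gives > 100000 nM, also a limit of the assay.

Among the measured compounds shown here, compound 2 therefore stands at no number but at a limit, and the same holds for the one other value in the set. For the measured compounds named here, the single step, a step that the two limits leave unreadable from compound 1 to compound 2, cannot be read for size or direction, since both ends sit at the limit of > 100000 nM in this assay, at which 2 of the 2 values shown sit.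

Compound 3 `CN(C)CCn1cnnc1-c1cc(Oc2ccc(NC(=O)N/N=C/c3ccc(O)cc3)cc2F)ccn1` has not been measured. It differs from compound 2 by 4-hydroxyphenyl in place of 3,5-dibromo-4-hydroxyphenyl on a carbon with a double bond to nitrogen. Going by the values given here, the only step available for comparison bears on the same position, but it gives no readable size, so nothing here points to a move away from the limit in either direction. The expectation for compound 3 is that the step that the limit leaves unreadable from compound 2 to compound 3 stays unresolved by the assay. Compound 3 is accordingly estimated at 150000 nM, with a range from 50000 nM to 500000 nM, and most likely reported as a limit rather than a number.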

Compound 3, half-maximal inhibitory concentration: 3560 nM
Beside the measured number, compound 3's estimate is 42-fold (1.62 log units) above it; measured number outside the range, below it.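

In this assay, the aryl group on the carbon with a double bond to nitrogen proves able to bring the series off the limit: 4-hydroxyphenyl in place of 3,5-dibromo-4-hydroxyphenyl gives an at least 28-fold lower number from compound 2 to compound 3 (1.44 log units; beyond the scatter). The second comparison at the same aryl group, hydrogen in place of hydroxy on an aromatic carbon, gives an at least 28-fold lower number from compound 1 to compound 3 (1.44 log units; beyond the scatter), so removing either the two bromine atoms or the second hydroxy yields a readable number, and the substitution of this ring matters in this assay. The step between compound 1 and compound 2 still cannot be read, and the true sizes of both new steps stay hidden, as only compound 3 gives a number and the other two sit at a shared limit of the assay: the limit of > 100000 nM in this assay, at which 2 of the 3 values shown sit.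

The compounds shown leave open whether the remaining hydroxy of compound 3 is needed at all, a question that an unsubstituted phenyl or a 4-methoxyphenyl group would address. They also leave open whether a ring with one bromine or with a chlorine in its place stays at the limit or gives a number.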